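Chloro in place of hydrogen, tested on two cores

The compounds below may be only part of what the source reports. "The series", "measured", "known", "first", "only" and "open" are said of these compounds alone.

Measured so far:
compound 1 `NC(=O)c1cc(-c2ccc(OC(=O)NC3CCCCC3)cc2)n(-c2ccccc2)n1`: 71 nM
compound 2 `NC(=O)c1cc(-c2ccc(OC(=O)NC3CCCCC3)cc2)n(-c2ccc(Cl)cc2)n1`: 172 nM
compound 3 `CCOC(=O)c1cc(-c2cccc(OC(=O)NC3CCCCC3)c2)nn1-c1ccccc1`: 539 nM

In an assay on isolated protein for inhibition of Fatty-acid amide hydrolase 1 (Homo sapiens), read by fluorescence, with a stated time of 30 min (on this read-out higher numbers stand for weaker inhibition and lower numbers for stronger inhibition), compound 1 gives 71 nM, compound 2 gives 172 nM and compound 3 gives 539 nM. Compound 2 differs from compound 1 by chloro in place of hydrogen on an aromatic carbon; the step is a 2.4-fold higher number from compound 1 to compound 2 (0.38 log units; beyond the scatter). Compound 3 rests on another core, and the difference between the two cores is not broken down here; its number is the highest of the three, beyond the scatter in both comparisons.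

Compound 4 `CCOC(=O)c1cc(-c2cccc(OC(=O)NC3CCCCC3)c2)nn1-c1ccc(Cl)cc1` has not been measured. It differs from compound 3 by chloro in place of hydrogen on an aromatic carbon, which is the same change as from compound 1 to compound 2, made at the same place on the other core. For the measured compounds named here, only one earlier instance of this change exists, so the expectation rests on it alone. A step of a 2.4-fold higher number from compound 3 to compound 4 (0.38 log units; beyond the scatter) is expected for compound 4 because a 2.4-fold higher number from compound 1 to compound 2 (0.38 log units; beyond the scatter). Compound 4 is therefore estimated in this assay at 1300 nM, with a likely range from 500 nM to 3500 nM.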

Compound 4, half-maximal inhibitory concentration: 353 nM
Beside the measured number, compound 4's estimate is 3.7-fold (0.57 log units) above it, and the stated range ends above it.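

In this assay, phenyl to 4-chlorophenyl on the core of compound 3 gives a 1.5-fold lower number from compound 3 to compound 4 (0.18 log units; within the scatter), so the clear rise in the number seen on the core of compound 1 does not reappear here. Set side by side, the two instances disagree, and the size of this step does not carry over from one core to the other in this series: the same change on two cores in this assay, a 2.4-fold higher number (0.38 log units; beyond the scatter) from compound 1 to compound 2 and a 1.5-fold lower number (0.18 log units; within the scatter) from compound 3 to compound 4, 3.7-fold (0.57 log units) apart, beyond the scatter of two such steps. For the compounds shown here, this shows only that the step differs across these two pairs; it does not show which feature of the two cores goes with the difference, and two pairs give no rule for a further core.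

Still open, going by these compounds, is whether other groups at the same place on the ring, such as fluoro, methoxy or methyl, would also give different steps on the two cores. Also open, on these data alone, is how a carboxylic acid in place of the ethyl ester would read on the core of compound 3, with and without the chloro.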